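Replacing the Hydroxybutynyl Arm of Compound 1 with Benzothiophene

The source may hold more compounds than are shown below. What is called first, only, known or untested is meant among the compounds shown, and "the series" means these compounds.

This account follows one step in a small series measured in an ADME assay (liver) for metabolic stability, with Liver microsome (Rattus norvegicus) as the target, using microsomes and NADPH, with a stated time of 30 min, tested at 1 uM; on this read-out lower numbers stand for slow clearance and higher numbers for fast clearance. Compound 1, with structure `Nc1ccc(S(=O)(=O)N2CCN(c3ncc(C(O)(C(F)(F)F)C(F)(F)F)cc3C#CCCO)CC2)cn1`, gives 68 mL.min-1.g-1 in this assay, the highest of the three measured numbers. Compound 2, with structure `Nc1ccc(S(=O)(=O)N2CCN(c3ncc(C(O)(C(F)(F)F)C(F)(F)F)cc3-c3ccoc3)CC2)cn1`, gives 57 mL.min-1.g-1, and compound 3, with structure `Nc1ccc(S(=O)(=O)N2CCN(c3ncc(C(O)(C(F)(F)F)C(F)(F)F)cc3-c3cncc(F)c3)CC2)cn1`, gives 19 mL.min-1.g-1. The step of a 1.2-fold lower number from compound 1 to compound 2 (0.08 log units; within the scatter) lies within the scatter, whereas a 3.6-fold lower number from compound 1 to compound 3 (0.55 log units; beyond the scatter) and a 3.0-fold lower number from compound 2 to compound 3 (0.48 log units; beyond the scatter) are modest but clear movements downward.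

Compound 4, with structure `Nc1ccc(S(=O)(=O)N2CCN(c3ncc(C(O)(C(F)(F)F)C(F)(F)F)cc3-c3ccc4sccc4c3)CC2)cn1`, has not yet been measured. Its change from compound 1 is 1-benzothiophen-5-yl in place of 4-hydroxybut-1-yn-1-yl on an aromatic carbon. Among the compounds with values here, two measured steps bear on it: both exchange the same 4-hydroxybut-1-yn-1-yl group for an aromatic ring on the same aromatic carbon of the shared core. The furan-3-yl step gave no movement beyond the scatter, while the 5-fluoropyridin-3-yl step gave a modest drop. The entering 1-benzothiophen-5-yl is a two-ring group unlike either, so the writer expects a step of a 1.1-fold higher number from compound 1 to compound 4 (0.04 log units; within the scatter) that stays within the scatter, with no clear direction. For compound 4 the estimated value in this assay is 75 mL.min-1.g-1, expected to fall between 35 mL.min-1.g-1 and 150 mL.min-1.g-1.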

Compound 4, intrinsic clearance in microsomes: 487 mL.min-1.g-1
Compound 4: middle estimate off by 6.5-fold (0.81 log units), on the low side; the whole stated range lies below it.
By their numbers in this assay, from the lowest: compound 3; then compounds 2 and 1 (each within the scatter of the next); then compound 4.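

In this assay, the 1-benzothiophen-5-yl group shows that this aromatic carbon can also push the number sharply upward, with a 7.2-fold higher number from compound 1 to compound 4 (0.86 log units; beyond the scatter) and an 8.5-fold higher number from compound 2 to compound 4 (0.93 log units; beyond the scatter), whereas the earlier replacements of the 4-hydroxybut-1-yn-1-yl arm left it within the scatter or lowered it. The largest step in the set, a 26-fold higher number from compound 3 to compound 4 (1.41 log units; beyond the scatter), separates two aromatic groups on the same carbon, so swapping the arm for an aromatic ring does not by itself fix the outcome, and the identity of the entering ring counts for a great deal. Nothing available accounts for the standing of compound 4 apart from the other compounds.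

The compounds shown leave open whether the rise belongs to the two-ring shape of the entering group or to its sulfur, a question that a 1-benzofuran-5-yl group, with oxygen in place of sulfur, or a naphthalen-2-yl group, of carbon only, could help to answer. Also open, as far as these compounds go, is whether a carboxylic acid or an amine carried on the benzothiophene would bring the number back toward that of compound 3.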